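Amide aryl variation, compound 2 to compound 3

The compounds below may be only part of what the source reports. "The series", "measured", "known", "first", "only" and "open" are said of these compounds alone.

compound 1 `Cc1occc1-c1nnc(SCC(=O)Nc2ccc(F)cc2)n1Cc1ccco1` — in a functional assay on CHO cells for antagonist activity at Orexin/Hypocretin receptor type 1 (Homo sapiens), read by FLIPR and calcium flux (a higher number here means a weaker inhibitor, a lower number a stronger inhibitor), compound 1 gives > 15800 nM, a limit of the assay.
compound 2 `COc1ccccc1NC(=O)CSc1nnc(-c2ccoc2C)n1Cc1ccco1` — in this assay compound 2 gives > 15800 nM, also a limit.

Because both values are limits, the step that the two limits leave unreadable from compound 1 to compound 2 cannot be read. Compound 2 therefore stands at the limit recorded by the limit of > 15800 nM in this assay, at which 2 of the 2 values shown sit. Compound 3 `COc1ccc(NC(=O)CSc2nnc(-c3ccoc3C)n2Cc2ccco2)cc1` differs from compound 2 by 4-methoxyphenyl in place of 2-methoxyphenyl on an amide-type nitrogen. No readable measured step bears on this change, so the expectation rests on compound 2 alone. A value at or beyond the limit is expected for compound 3, estimated at 20000 nM (8000 nM to 60000 nM). This expected step is a step that the limit leaves unreadable from compound 2 to compound 3.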

Compound 3, inhibition constant: > 15800 nM
Compound 3 gave a limit, no number; the forecaster's own chance of this, stated with the estimate: 85%; the middle value lies beyond the limit too.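

No step among compound 1, compound 2 and compound 3 can be read, as all three sit at one limit: the limit of > 15800 nM in this assay, at which 3 of the 3 values shown sit.

The compounds shown leave open whether any aryl group on the amide nitrogen of the shared core gives a readable value in this assay.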